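This account rests on a few compounds, and the source may have more. Where it says the series, first, only, none or still open, it means among the compounds named here.

Compound 3 `COc1cc(N(C)CCN(C)C)c(NC(=O)/C=C\C(C)C)cc1Nc1nccc(-c2cn(C)c3ccccc23)n1` gives 1820 nM in a functional assay on NCI-H1975 cells (Homo sapiens) for antiproliferative activity, read by MTT assay, with a stated time of 72 h (on this read-out lower numbers stand for stronger inhibition and higher numbers for weaker inhibition), the lowest of the two numbers in hand. Compound 2 `C/C=C\C(=O)Nc1cc(Nc2nccc(-c3cn(C)c4ccccc34)n2)c(OC)cc1N(C)CCN(C)C` gives 4540 nM, and the step of a 2.5-fold lower number from compound 2 to compound 3 (0.40 log units; beyond the scatter) came with isopropyl in place of methyl on a double-bonded chain carbon. Compound 1 `COc1cc(N(C)CCN(C)C)c(NC(=O)C(Cl)=C(Cl)Cl)cc1Nc1nccc(-c2cn(C)c3ccccc23)n1` gives only a limit, > 50000 nM, not a number. Compound 4 `COc1cc(N(C)CCN(C)C)c(NC(=O)/C=C\C(C)C)cc1Nc1ncc(C#N)c(-c2cn(C)c3ccccc23)n1` differs from compound 3 by cyano in place of hydrogen on an aromatic carbon. All three measured steps change the group on the carbonyl carbon and leave the six-membered aromatic ring untouched, so none of them speaks directly to this change, and no step beyond the scatter is expected. Compound 4 is expected to give about 1500 nM, between 500 nM and 5000 nM, which means a 1.2-fold lower number from compound 3 to compound 4 (0.08 log units; within the scatter).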

Compound 4, half-maximal inhibitory concentration: 1110 nM
Compound 4: the middle estimate sits 1.4-fold (0.13 log units) above what was measured; low and high end bracket the measured number.
By their numbers in this assay, from the lowest: compounds 4 and 3 (each within the scatter of the next); then compound 2. At a limit, above all of these: compound 1.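

Unlike the earlier steps, which all changed the group on the carbonyl carbon, this one touches the six-membered aromatic ring with 2 nitrogen, ortho to the 1-methyl-1H-indol-3-yl group. In this assay, cyano in place of hydrogen there gives a 1.6-fold lower number from compound 3 to compound 4 (0.21 log units; within the scatter), so this position takes cyano without a change beyond the scatter. Nothing measured here offers a reason for this result.

From the compounds shown here alone, whether an amine, a carboxylic acid or a chlorine atom at this position would shift the number beyond the scatter stays open. So does whether cyano gives the same outcome alongside the prop-1-en-1-yl group of compound 2.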